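Indole thioacetamides: cytotoxicity on a human kidney cell line

A few compounds are considered here, and "the series" means these few. Any claim that something is new, unique, unknown or untested is made for them only; others in the source may bear on it.

Measured compounds in an ADME assay on HEK-293T cells (Homo sapiens) for cytotoxicity, read by CCK-8 assay, with a stated time of 48 h; on this read-out higher numbers stand for lower toxicity in this test and lower numbers for higher toxicity in this test:

compound 1, `CCOc1ccccc1NC(=O)CSc1c[nH]c2c(Cl)cccc12`, this assay > 100000 nM, a limit of the assay
compound 2, `CCOc1ccccc1NC(=O)CSc1c[nH]c2c(OC)cccc12`, this assay > 100000 nM, a limit of the assay
compound 3, `CCOc1ccccc1NC(=O)CSc1c[nH]c2ccc(OC)cc12`, this assay > 100000 nM, a limit of the assay

All three measured members of the series sit at the same limit in this assay, (the limit of > 100000 nM in this assay, at which 3 of the 3 values shown sit); none returns a number. Compound 2 and compound 1 share a core and differ in one place, (chloro in place of methoxy on an aromatic carbon). The step that the two limits leave unreadable from compound 2 to compound 1 cannot be read, since both ends are limits. Compound 2 and compound 3 have the same atoms joined differently; the difference between the two cores is not broken down here.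

The unmeasured compound 4, `CCOc1ccccc1NC(=O)CSc1c[nH]c2ccc(Cl)cc12`, stands to compound 3 as compound 1 stands to compound 2: chloro in place of methoxy on an aromatic carbon. It is the same kind of change as from compound 2 to compound 1, not the same change: there the place was ortho to a fused ring and meta to a fused ring, here it is meta to a fused ring and para to a fused ring.

Compound 4 is expected to remain at the limit in this assay because compound 3 sits at the limit of > 100000 nM in this assay, at which 3 of the 3 values shown sit, and the same kind of change elsewhere on the core left compound 1 there as well. The expected step that the limit leaves unreadable from compound 3 to compound 4 is therefore estimated to be nil within what the assay can show. Compound 4 is estimated at 150000 nM, from 80000 nM to 500000 nM.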

Compound 4, half-maximal cytotoxic concentration: 37600 nM
The estimate for compound 4 lay 4.0-fold (0.60 log units) above the measured number; measured number below the stated range.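

In this assay, chloro in place of methoxy on an aromatic carbon, meta to a fused ring and para to a fused ring, gives an at least 2.6-fold lower number from compound 3 to compound 4 (0.42 log units; beyond the scatter), and the true size of this step may be larger, since its starting point is only a limit. Compound 1, which carries the chloro at the other place, gives > 100000 nM, and this is a limit of the assay, not a number. The steps between limits cannot be read, so the series shows a lower number for this change on one core only; it neither shows that the change carries over to the other core with the same size nor that it fails to carry over, and compound 4 remains the single member with a number: the limit of > 100000 nM in this assay, at which 3 of the 4 values shown sit.

Open, going by these compounds, is whether the lower number in compound 4 belongs to chloro as such or would also appear with another group in its place, such as fluoro, bromo, trifluoromethyl or an amine. Also open, on these data alone, is how a carboxylic acid or a longer chain in place of the ethoxy group would shift the number of compound 4 in this assay.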